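Trading One Aromatic Ring for Another: Expected Oral Bioavailability

A few compounds are considered here, and "the series" means these few. Any claim that something is new, unique, unknown or untested is made for them only; others in the source may bear on it.

Of the compounds shown here, two have so far been measured in an ADME assay on the whole organism (Mus musculus, strain BALB/c) for pharmacokinetics, read by HPLC, with a stated time of 24 h, at a dose of 12.5 mg/kg by the oral route; on this read-out lower numbers stand for lower oral bioavailability and higher numbers for higher oral bioavailability. Compound 1 `CC(c1ccc(OC(F)(F)F)cc1)N1CC2(CCN(c3nc(=O)c4cc(C(F)(F)F)cc([N+](=O)[O-])c4s3)CC2)C1` gives 24.2%. Compound 2 `O=c1nc(N2CCN(CC3CCCCC3)CC2)sc2c([N+](=O)[O-])cc(C(F)(F)F)cc12` gives 11.8%. Compound 1 therefore stands highest of the two numbers, and its gap to compound 2 lies beyond the scatter. Among the compounds with values here, no pair of measured compounds differs in only one place, so nothing here shows how a single small change moves the read-out.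

Compound 3 `CC(c1ccc(Cl)c(F)c1)N1CC2(CCN(c3nc(=O)c4cc(C(F)(F)F)cc([N+](=O)[O-])c4s3)CC2)C1` is the next candidate and differs from compound 1 in one place: 4-chloro-3-fluorophenyl in place of 4-(trifluoromethoxy)phenyl on a saturated chain carbon bound to an amine nitrogen in a ring and a saturated chain carbon. The shared core stays untouched.

Within the data shown here, with no single-change step to lean on, the expected step from compound 1 to compound 3 in this assay is a number 2.2 percentage points lower from compound 1 to compound 3 (within the scatter), which is within the scatter. Compound 3 is estimated at 22%, with a likely range from 8% to 40%.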

Compound 3, oral bioavailability: 33%
Estimate against measurement, compound 3: 11 percentage points below; low and high end bracket the measured number.
By their numbers in this assay, from the lowest: compound 2; then compounds 1 and 3 (each within the scatter of the next).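

In this assay, putting 4-chloro-3-fluorophenyl in place of 4-(trifluoromethoxy)phenyl on a saturated chain carbon bound to an amine nitrogen in a ring and a saturated chain carbon gives a number 8.8 percentage points higher from compound 1 to compound 3 (within the scatter). At this position, then, one aromatic ring carrying halogens can stand in for another without a step that can be told from the usual scatter, even though the group goes from 11 heavy atoms to 8 and from 1 hydrogen-bond acceptor to 0. No measurement offered here accounts for this result.

This is a single exchange between two phenyl groups, so it gives no general rule for the position. Still open, as far as these compounds go, is how oral bioavailability would respond to a pyridine ring here, or to a phenyl ring bearing a nitrile.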